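Compound 3 to compound 4: cyano to trifluoromethyl

The source may hold more compounds than are shown below. What is called first, only, known or untested is meant among the compounds shown, and "the series" means these compounds.

Three amides sharing one core have been read in a functional assay on A549 cells (Homo sapiens) for inhibition, read by CCK-8 assay, with a stated time of 72 h, tested at 10 uM; on this read-out higher numbers stand for more inhibition of growth at the one concentration tested and lower numbers for less inhibition of growth. Compound 1 (`CN(C)C(=O)c1cc2cnc(Nc3ccc(NC(=O)C4(C(=O)Nc5ccc(Cl)cc5)CC4)cc3)nc2n1C1CCCC1`) gives (101%), compound 2 (`CN(C)C(=O)c1cc2cnc(Nc3ccc(NC(=O)C4(C(=O)Nc5ccccc5F)CC4)cc3)nc2n1C1CCCC1`) gives (88.6%) and compound 3 (`CN(C)C(=O)c1cc2cnc(Nc3ccc(NC(=O)C4(C(=O)Nc5cccc(C#N)c5)CC4)cc3)nc2n1C1CCCC1`) gives (73.6%). Compound 3 is the lowest of the three, beyond the scatter from both of the others.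

Compound 4 (`CN(C)C(=O)c1cc2cnc(Nc3ccc(NC(=O)C4(C(=O)Nc5cccc(C(F)(F)F)c5)CC4)cc3)nc2n1C1CCCC1`) has trifluoromethyl in place of cyano on an aromatic carbon, meta to a large group (trifluoromethyl in place of cyano on an aromatic carbon).

Within the data shown here, three measured steps bear on this change, all modest and beyond the scatter, and all made in the aryl group on the amide nitrogen: 2-fluorophenyl for 4-chlorophenyl (a number 12.4 percentage points lower from compound 1 to compound 2 (beyond the scatter)), 3-cyanophenyl for 4-chlorophenyl (a number 27.4 percentage points lower from compound 1 to compound 3 (beyond the scatter)) and 3-cyanophenyl for 2-fluorophenyl (a number 15 percentage points lower from compound 2 to compound 3 (beyond the scatter)). Among the measured compounds shown here, no measured compound carries trifluoromethyl, so these steps give a scale and no direct precedent. For the measured compounds named here, both replacements of a halogen-bearing aryl group by 3-cyanophenyl lowered the number, and no measured compound goes against this, though only three are available.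

The expected move in this assay is upward and of modest size (a number 13.4 percentage points higher from compound 3 to compound 4 (beyond the scatter)). For compound 4 the estimated value is 87% with an expected range from 71% to 102%.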

Compound 4, percent growth inhibition at one concentration: 89.2%
Compound 4: middle estimate off by 2.2 percentage points, on the low side; the measured number falls inside the stated range.
By their numbers in this assay, from the lowest: compound 3; then compounds 2 and 4 (each within the scatter of the next); then compound 1.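

At the aromatic carbon meta to a large group, the group itself matters in this assay: with the ring position held fixed, a number 15.6 percentage points higher from compound 3 to compound 4 (beyond the scatter), so the low number of compound 3 goes with the nitrile and not with substitution at this carbon as such. Among the aryl groups on the amide nitrogen, 3-(trifluoromethyl)phenyl cannot be told apart from 2-fluorophenyl, a number 0.6 percentage points higher from compound 2 to compound 4 (within the scatter), but it does not match 4-chlorophenyl, a number 11.8 percentage points lower from compound 1 to compound 4 (beyond the scatter), so compound 1 remains the highest of the four by a margin beyond the scatter. Nothing measured here on the groups themselves accounts for these differences, and the step stands as an empirical observation only.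

On these data alone, it remains open whether a methoxy group, an amine or a carboxylic acid on this same carbon would read closer to compound 4 or to compound 3. Chlorine on this carbon is also absent from the compounds shown, so the gap to compound 1 cannot yet be divided between the identity of the group and its place on the ring.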